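The compounds below may be only part of what the source reports. "The series", "measured", "known", "first", "only" and "open" are said of these compounds alone.

Compound 2 `O=C(Nc1nc2ccc(F)cc2s1)c1cn(-c2ccccc2)nc1-c1ccc(F)cc1` gives 5260 nM in a functional assay on PC-3 cells (Homo sapiens) for cytotoxicity, read by MTT assay, with a stated time of 72 h (on this read-out higher numbers stand for weaker inhibition and lower numbers for stronger inhibition), the higher of the two numbers obtained so far, while compound 1 `O=C(Nc1nc2ccc(Cl)cc2s1)c1cn(-c2ccccc2)nc1-c1ccccc1` gives 3690 nM in this assay; the two values lie within the scatter of each other, so no order can be drawn from them. Compound 3 `O=C(Nc1nc2ccc(Cl)cc2s1)c1cn(-c2ccccc2)nc1-c1ccc(F)cc1` has not yet been measured; it differs from compound 2 by chloro in place of fluoro on an aromatic carbon. Within the data shown here, no measured step of this kind is on hand. Compound 1, carrying the same chloro group, gives a number close to compound 2, so no step beyond the scatter is expected, a 1.3-fold lower number from compound 2 to compound 3 (0.12 log units; within the scatter). For compound 3 the value is estimated at 4000 nM, likely between 2000 nM and 9000 nM.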

Compound 3, half-maximal inhibitory concentration: 3170 nM
Compound 3: middle estimate off by 1.3-fold (0.10 log units), on the high side; low and high end bracket the measured number.
By their numbers in this assay, from the lowest: compounds 3, 1 and 2 (each within the scatter of the next).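

In this assay the change from 6-fluoro-1,3-benzothiazol-2-yl to 6-chloro-1,3-benzothiazol-2-yl now has a measured step, a 1.7-fold lower number from compound 2 to compound 3 (0.22 log units; within the scatter) and so stays within the scatter. Fluoro in place of hydrogen on an aromatic carbon gives a 1.2-fold lower number from compound 1 to compound 3 (0.07 log units; within the scatter) and also stays within the scatter, so neither change separates these compounds. No evidence on hand bears on this result. As far as these compounds go, whether an amine, a carboxylic acid or plain hydrogen at the halogen position of the fused system would move the number beyond the scatter remains open.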